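A few compounds are considered here, and "the series" means these few. Any claim that something is new, unique, unknown or untested is made for them only; others in the source may bear on it.

In a functional assay on VCaP cells (Homo sapiens) for antiproliferative activity, read by propidium iodide staining, with a stated time of 96 h (on this read-out lower numbers stand for stronger inhibition and higher numbers for weaker inhibition), compound 3 `CC(O)(COc1ccc(C(F)(F)F)cc1)C(=O)Nc1cccc(S(F)(F)(F)(F)F)c1` gives 13300 nM. That number falls inside the span set by compound 2 `CC(O)(COc1ccc(S(F)(F)(F)(F)F)cc1)C(=O)Nc1cccc(S(F)(F)(F)(F)F)c1` at 8000 nM and compound 1 `CC(O)(CSc1ccccc1C(F)(F)F)C(=O)Nc1cccc(S(F)(F)(F)(F)F)c1` at 21000 nM, and it lies within the scatter of each. Compound 4 `CC(O)(COc1ccccc1C(F)(F)F)C(=O)Nc1cccc(S(F)(F)(F)(F)F)c1` has the same atoms as compound 3, joined differently: 2-(trifluoromethyl)phenyl in place of 4-(trifluoromethyl)phenyl on an oxygen on a saturated carbon. In short, 2-(trifluoromethyl)phenyl stands in place of 4-(trifluoromethyl)phenyl on an oxygen on a saturated carbon. Among the measured compounds shown here, no measured step moves this group in this way, so the evidence is indirect. For the measured compounds named here, the one measured step, a 1.7-fold higher number from compound 2 to compound 3 (0.22 log units; within the scatter), replaces a group on the same ring and stays within the scatter. Compound 1, at 21000 nM, carries the same 2-(trifluoromethyl)phenyl group, but on a sulfur rather than an oxygen. A small upward drift is therefore expected at most, and the estimated change, a 1.1-fold higher number from compound 3 to compound 4 (0.05 log units; within the scatter), stays within the scatter. The expected value for compound 4 is 15000 nM, with an estimated range from 6500 nM to 35000 nM.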

Compound 4, half-maximal inhibitory concentration: 36700 nM
Beside the measured number, compound 4's estimate is 2.4-fold (0.39 log units) below it; measured number outside the range, above it.
By their numbers in this assay, from the lowest: compounds 2, 3, 1 and 4 (each within the scatter of the next, the first and the last beyond it).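

In this assay, two compounds built from the same atoms separate clearly: a 2.8-fold higher number from compound 3 to compound 4 (0.44 log units; beyond the scatter), with 2-(trifluoromethyl)phenyl in place of 4-(trifluoromethyl)phenyl on an oxygen on a saturated carbon. Among the compounds shown here, this modest step is the first in the set to pass beyond the scatter, so the arrangement of this group matters here, even though the counts of atoms, donors and acceptors in the two groups are identical. Nothing measured here explains why the 2-(trifluoromethyl)phenyl compound gives weaker inhibition.

Compound 1 at 21000 nM and compound 4 at 36700 nM lie within the scatter of each other, so a sulfur or an oxygen carrying 2-(trifluoromethyl)phenyl cannot be told apart on these numbers. On these data alone, whether a chlorine atom or a nitrile in place of the trifluoromethyl on that ring would give a similar number remains open.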